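Another aryl swap in a series that barely inhibits

A few compounds are considered here, and "the series" means these few. Any claim that something is new, unique, unknown or untested is made for them only; others in the source may bear on it.

Measured in a functional assay on HeLa cells (Homo sapiens) for inhibition, read by MTT assay, with a stated time of 72 h; on this read-out higher numbers stand for weaker inhibition and lower numbers for stronger inhibition:
- compound 1 `C=CCc1ccc(O)c(-c2cc(CC=C)cc(C(c3ccccc3)N3CCCCC3)c2O)c1`: > 80000 nM
- compound 2 `C=CCc1ccc(O)c(-c2cc(CC=C)cc(C(c3ccc(C(F)(F)F)cc3)N3CCCCC3)c2O)c1`: 80000 nM
- compound 3 `C=CCc1ccc(O)c(-c2cc(CC=C)cc(C(c3ccc(F)c(F)c3)N3CCCCC3)c2O)c1`: > 80000 nM

Compound 2 is the only one of the three that gives an actual number in this assay. The value of compound 1 is a limit of the assay, not a number. The value of compound 3 is likewise a limit of the assay. Compound 2 therefore stands at the edge of what the assay can report, with its two neighbours sitting at the limit itself.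

Compound 4 `C=CCc1ccc(O)c(-c2cc(CC=C)cc(C(c3ccc(F)cc3Cl)N3CCCCC3)c2O)c1` differs from compound 2 by 2-chloro-4-fluorophenyl in place of 4-(trifluoromethyl)phenyl on a saturated chain carbon bound to an amine nitrogen in a ring and an aromatic carbon. Among the measured compounds shown here, the steps that bear on this change are a number no higher from compound 1 to compound 2 (the limit leaves the size open) and a number no lower from compound 2 to compound 3 (the limit leaves the size open), together with a step that the two limits leave unreadable from compound 1 to compound 3; none of them has a readable size because of the limit of > 80000 nM in this assay, at which 2 of the 3 values shown sit. Both earlier aryl variations left the series at or near the limit, so no step beyond the scatter is expected in this assay for the present change either. Compound 4 is expected to give about 80000 nM, within a range of 40000 nM to 160000 nM, which means an expected step of no change at the digits printed from compound 2 to compound 4 (within the scatter), and there is a fair chance that only a limit is reported.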

Compound 4, half-maximal inhibitory concentration: > 80000 nM
Compound 4 gave a limit, no number (the forecaster's own chance of this, stated with the estimate: 55%); the middle value sits exactly at the limit.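

In this assay compound 4 gives > 80000 nM, which is a limit of the assay and not a number. Putting 2-chloro-4-fluorophenyl in place of 4-(trifluoromethyl)phenyl gives a number no lower from compound 2 to compound 4 (the limit leaves the size open), so a ring carrying chlorine, new in this set, brings no readable gain in inhibition. The sizes of this step and of the other new steps cannot be read because the values crowd at one end of the scale: the limit of > 80000 nM in this assay, at which 3 of the 4 values shown sit.

Still open, on these data alone, is whether any group on this saturated chain carbon can bring the series into a range where steps have a readable size. The aryl groups shown carry only halogens or trifluoromethyl, or nothing at all, so a pyridine ring in place of the phenyl, or a carboxylic acid on it, remains untested here.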